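This account rests on a few compounds, and the source may have more. Where it says the series, first, only, none or still open, it means among the compounds named here.

Compound 1 `COc1ccc(/C=C/c2cc(OC)cc(OC)c2/C=C/C(=O)c2ccc(C)cc2)cc1`: 3.6 ug/mL
Compound 2 `COc1ccc(/C=C/c2cc(OC)cc(OC)c2/C=C/C(=O)c2ccc(C(F)(F)F)cc2)cc1`: 7.8 ug/mL
Compound 3 `COc1ccc(/C=C/c2cc(OC)cc(OC)c2/C=C/C(=O)c2ccc(OC)cc2)cc1`: not yet measured

In a functional assay on A549 cells (Homo sapiens) for antiproliferative activity, read by MTT assay, with a stated time of 48 h (a lower number here means a stronger inhibitor, a higher number a weaker inhibitor), compound 2 holds the higher of the two numbers, at 7.8 ug/mL. Compound 3 differs from it by methoxy in place of trifluoromethyl on an aromatic carbon. Among the compounds with values here, only one measured step bears on this change: a 2.2-fold higher number from compound 1 to compound 2 (0.34 log units; beyond the scatter), modest and beyond the scatter, where trifluoromethyl replaced methyl. Within the data shown here, no methoxy compound has been measured, so the reverse of that step is only a rough guide. A modest move to a lower number is expected, an estimated 1.7-fold lower number from compound 2 to compound 3 (0.24 log units; within the scatter). For compound 3 the expected value is 4.5 ug/mL, with an estimated range of 2.2 ug/mL to 9 ug/mL.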

Compound 3, half-maximal inhibitory concentration: 4.5 ug/mL
The estimate for compound 3 equals the measured number at the digits printed; measured number inside the range.
By their numbers in this assay, from the lowest: compounds 1, 3 and 2 (each within the scatter of the next, the first and the last beyond it).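

In this assay, methoxy on this aromatic carbon, para to a large group, cannot be told apart from either of the other two groups: a 1.7-fold lower number from compound 2 to compound 3 (0.24 log units; within the scatter) and a 1.3-fold higher number from compound 1 to compound 3 (0.10 log units; within the scatter) both stay within the scatter, even though compound 1 and compound 2 differ beyond it. Nothing measured here explains this result. The compounds shown leave open whether an amine, a hydroxyl or a carboxylic acid at this position would shift the number beyond the scatter. They also leave open what a longer chain such as ethoxy would do.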